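The source may report more compounds than this note shows. Statements on the series, on what has been measured and on what is new or still open speak of the compounds shown alone.

Compound 1 `COc1ccc(-n2cc(COc3ccc(/C=C/C(=O)c4ccc5c(c4O)CCC(C)(C)O5)cc3)nn2)c([N+](=O)[O-])c1` gives "not active" (no number reported)
Compound 2 `CC(=O)c1ccc(-n2cc(COc3ccc(/C=C/C(=O)c4ccc5c(c4O)CCC(C)(C)O5)cc3)nn2)cc1` gives 149000 nM
Compound 3 `CCc1ccccc1-n1cc(COc2ccc(/C=C/C(=O)c3ccc4c(c3O)CCC(C)(C)O4)cc2)nn1` gives 112000 nM

In a functional assay on A549 cells (Homo sapiens) for antiproliferative activity, read by MTT assay (a higher number here means a weaker inhibitor, a lower number a stronger inhibitor), compound 3 stands level with compound 2 within the scatter, and compound 1 yielded no number. Compound 4 `CC1(C)CCc2c(ccc(C(=O)/C=C/c3ccc(OCc4cn(Cc5ccc([N+](=O)[O-])cc5)nn4)cc3)c2O)O1` differs from compound 3 by 4-nitrobenzyl in place of 2-ethylphenyl on an aromatic nitrogen is the counted change. Within the data shown here, the only measured step at this place, a 1.3-fold lower number from compound 2 to compound 3 (0.12 log units; within the scatter), stayed within the scatter, though it involved no benzyl group, so it is a thin guide. A step of a 1.1-fold higher number from compound 3 to compound 4 (0.03 log units; within the scatter) is therefore expected, with no shift beyond the scatter in either direction. Compound 1 leaves open the chance of no number at all. For compound 4 the estimated value is 120000 nM, with an expected range from 45000 nM to 300000 nM in this readout.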

Compound 4, half-maximal inhibitory concentration: 69900 nM
Compound 4: middle estimate off by 1.7-fold (0.23 log units), on the high side; the range from low to high includes it.
By their numbers in this assay, from the lowest: compounds 4, 3 and 2 (each within the scatter of the next, the first and the last beyond it).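

In this assay, among these compounds, 4-nitrobenzyl on the aromatic nitrogen gives the first comparison of a benzyl group with the phenyl groups at this position. Set against 2-ethylphenyl it gives a 1.6-fold lower number from compound 3 to compound 4 (0.20 log units; within the scatter), while set against 4-acetylphenyl it gives a 2.1-fold lower number from compound 2 to compound 4 (0.33 log units; beyond the scatter), a modest gain that still leaves compound 4 a weak inhibitor. No evidence at hand bears on this result. Still open, from the compounds shown here alone, is whether a benzyl group carrying an amine or a carboxylic acid instead of the nitro group, or a longer chain to the ring, would move the number further.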